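This account rests on a few compounds, and the source may have more. Where it says the series, first, only, none or still open, it means among the compounds named here.

Compound 2, `COc1cc(O)cc(O)c1C(=O)/C=C/c1ccco1`, gives the higher of the two numbers recorded in a toxicity assay on cells (Macrophage, Mus musculus, strain BALB/c) for cytotoxicity, read by MTT assay (on this read-out higher numbers stand for weaker inhibition and lower numbers for stronger inhibition), at 384000 nM. Compound 1, `C=CCOc1cc(OC)c(C(=O)/C=C/Cc2ccccc2)c(OCC=C)c1`, gives the lower number in this assay, at 14800 nM, a gap that lies beyond the scatter. Compound 3, `COc1cc(O)cc(O)c1C(=O)/C=C/c1ccc(F)cc1`, is not yet measured; it differs from compound 2 by 4-fluorophenyl in place of furan-2-yl on a double-bonded chain carbon bound to a double-bonded chain carbon. With no comparable change among the measured pair, only a small step toward a lower number is expected, a 1.7-fold lower number from compound 2 to compound 3 (0.24 log units; within the scatter), likely not beyond the scatter. Compound 3 is therefore estimated at 220000 nM, within 70000 nM to 650000 nM.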

Compound 3, half-maximal inhibitory concentration: 28800 nM
Estimate against measurement, compound 3: 7.6-fold (0.88 log units) above; the measured number lies below the stated range.
By their numbers in this assay, from the lowest: compounds 1 and 3 (each within the scatter of the next); then compound 2.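

Placed on a double-bonded chain carbon bound to a double-bonded chain carbon, the ring is far from a silent part of the structure: in this assay, 4-fluorophenyl in place of furan-2-yl gives a 13-fold lower number from compound 2 to compound 3 (1.12 log units; beyond the scatter) on an otherwise unchanged core. This is the first change in one place among the compounds shown, and its size lies beyond the scatter. Nothing at hand bears on what lies behind this step.

The compounds shown leave open whether the fluorine or the six-membered ring carries the step, since they include no unsubstituted phenyl at this place. On these data alone, how a phenyl bearing an amine or a carboxylic acid would read here also stays open.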